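The source may report more compounds than this note shows. Statements on the series, on what has been measured and on what is new or still open speak of the compounds shown alone.

Working notes on the series. Compound 2 `NS(=O)(=O)NCCSc1nonc1/C(=N/O)Nc1ccc(F)c(Br)c1` has been run in an assay for inhibition of Indoleamine 2,3-dioxygenase 1 (Homo sapiens), read by fluorescence, with a stated time of 1 h (a higher number here means a weaker inhibitor, a lower number a stronger inhibitor), and compound 2 gives 130 nM. Compound 1 `C[C@H](CSc1nonc1/C(=N/O)Nc1ccc(F)c(Br)c1)NC(=O)CS(N)(=O)=O` gives 110 nM in this assay. On these two numbers compound 2 holds the higher value, with compound 1 the nearest, and the pair sit within the scatter of each other, so the two values show no separation that can be read. Going by the values given here, the two structures differ in more than one place, so no single step between them is available.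

Compound 3 `CS(=O)(=O)NCCSc1nonc1/C(=N/O)Nc1ccc(F)c(Br)c1` is not yet measured in this assay. It differs from compound 2 in one place: methyl in place of amino on a sulfonyl sulfur. The rest of the structure is unchanged. Among the compounds with values here, nothing measured so far covers this change, so the expectation rests on the change alone: a step of modest size at most, toward a higher number if any, and plausibly none beyond the scatter. Compound 3 is expected to give about 180 nM in this assay, within a range of 80 nM to 400 nM. That estimate corresponds to an expected step of a 1.4-fold higher number from compound 2 to compound 3 (0.14 log units; within the scatter).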

Compound 3, half-maximal inhibitory concentration: 270 nM
Beside the measured number, compound 3's estimate is 1.5-fold (0.18 log units) below it; the measured number falls inside the stated range.
By their numbers in this assay, from the lowest: compounds 1 and 2 (each within the scatter of the next); then compound 3.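

In this assay, going by these compounds alone, methyl in place of amino on a sulfonyl sulfur whose other neighbour is the sulfonamide nitrogen gives a 2.1-fold higher number from compound 2 to compound 3 (0.32 log units; beyond the scatter), the first single-change reading at this position and one that shows this position is not silent to the change, although the step is modest. The amino group that leaves counts as a hydrogen-bond donor and the methyl that enters does not, but this one pair cannot separate that difference from the other differences between the two groups, so it gives a direction for this single change and no general rule for the position. No measurement in hand accounts for the higher number seen with methyl.

Still open, going by these compounds, is how other groups on the same sulfur would read, such as ethyl, cyclopropyl or dimethylamino, since amino and methyl are the only two compared here. Also open, on these data alone, is whether methyl in place of amino would give a step of similar size in the side chain of compound 1, which differs from compound 2 in more than one place.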